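Replacing the Phenylethynyl Arm with a Fluorophenylethyl Chain

The compounds below may be only part of what the source reports. "The series", "measured", "known", "first", "only" and "open" are said of these compounds alone.

Of the compounds shown here, three sharing one amide core have been measured in an assay on CHO cells for antagonist activity at transient receptor potential cation channel subfamily V member 1 (Homo sapiens), read by FLIPR; on this read-out higher numbers stand for weaker inhibition and lower numbers for stronger inhibition. Compound 1 `Cc1cc(-c2nc(C(F)(F)F)ccc2CNC(=O)C(C)c2ccc(NS(C)(=O)=O)c(F)c2)ccc1F` gives 0.4 nM, compound 2 `CC(C(=O)NCc1ccc(C(F)(F)F)nc1-c1ccc2cc[nH]c2c1)c1ccc(NS(C)(=O)=O)c(F)c1` gives 20.3 nM, and compound 3 `CC(C(=O)NCc1ccc(C(F)(F)F)nc1C#Cc1ccccc1)c1ccc(NS(C)(=O)=O)c(F)c1` gives 0.8 nM. Compound 3 therefore stands second highest of the three numbers: its nearest neighbour is compound 1, and the pair differ only within the scatter, as a 2.0-fold higher number from compound 1 to compound 3 (0.30 log units; within the scatter) shows, while compound 2 is the furthest, as seen in a 25-fold lower number from compound 2 to compound 3 (1.40 log units; beyond the scatter).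

Compound 4 `CC(C(=O)NCc1ccc(C(F)(F)F)nc1CCc1ccc(F)cc1)c1ccc(NS(C)(=O)=O)c(F)c1` differs from compound 3 in one place: 2-(4-fluorophenyl)ethyl in place of 2-phenylethynyl on an aromatic carbon. Among the measured compounds shown here, no measured step changes the same position in the same way. For the measured compounds named here, the steps that bear on it are those that swap the group at this position: a 51-fold higher number from compound 1 to compound 2 (1.71 log units; beyond the scatter) was large, whereas a 2.0-fold higher number from compound 1 to compound 3 (0.30 log units; within the scatter) stayed within the scatter. Two quite different groups on this carbon, in compound 1 and compound 3, thus both gave low numbers, and only the indolyl of compound 2 pushed the number up sharply.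

On that basis compound 4 is expected to give a number close to compound 3, with a modest move upward allowed for the untested linker, a 3.8-fold higher number from compound 3 to compound 4 (0.57 log units; beyond the scatter). The estimate for compound 4 in this assay is 3 nM, within a range from 0.6 nM to 15 nM.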

Compound 4, inhibition constant: 1.8 nM
Compound 4: middle estimate off by 1.7-fold (0.22 log units), on the high side, within the range that was stated.
By their numbers in this assay, from the lowest: compounds 1 and 3 (each within the scatter of the next); then compound 4; then compound 2.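

In this assay, the aromatic carbon next to the ring nitrogen accepts a chain without a triple bond at only a modest cost, a 2.3-fold higher number from compound 3 to compound 4 (0.35 log units; beyond the scatter). The 2-(4-fluorophenyl)ethyl group stays far ahead of the 1H-indol-6-yl group, an 11-fold lower number from compound 2 to compound 4 (1.05 log units; beyond the scatter), but falls short of the 4-fluoro-3-methylphenyl group, a 4.5-fold higher number from compound 1 to compound 4 (0.65 log units; beyond the scatter), so this position separates groups beyond the single sharp jump seen with compound 2, even among those that give low numbers. Nothing available here accounts for these differences.

The compounds shown leave open whether the higher number of compound 4 goes with the loss of the triple bond or with the added fluorine, since the two changes arrive together. They also leave open how a 2-phenylethyl group, a longer 3-(4-fluorophenyl)propyl chain or an amine on this carbon would compare.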